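This account rests on a few compounds, and the source may have more. Where it says the series, first, only, none or still open, it means among the compounds named here.

Of the compounds shown here, two built on a shared core have been measured in a functional assay on A549 cells (Homo sapiens) for inhibition, read by MTT assay, with a stated time of 72 h; a lower number here means a stronger inhibitor, a higher number a weaker inhibitor. Compound 1 `Cc1ccc2c(c1)/C(=N/NC(=S)N1CCN(c3ccccc3)CC1)C(=O)N2` gives 9880 nM in this assay. Compound 2 `Cc1ccccc1N1CCN(C(=S)N/N=C2\C(=O)Nc3ccc(Cl)cc32)CC1` gives 6520 nM in this assay. These two numbers lie within the usual scatter of repeated measurements of each other, so this assay cannot separate compound 1 from compound 2, and compound 2 is simply the starting point for the next step.

Compound 3 `O=C1Nc2ccc(Cl)cc2/C1=N/NC(=S)N1CCN(c2ccccc2[N+](=O)[O-])CC1` has not yet been measured in this assay. It differs from compound 2 in one place: nitro in place of methyl on an aromatic carbon. The exchange sits on the six-membered aromatic ring of carbon only, ortho to a large group, as the difference describes.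

For the measured compounds named here, no measured pair shows what this particular exchange does, so nothing comparable can be read off from the numbers in hand. Resting only on compound 2 and the size of the change, the step from compound 2 to compound 3 is expected to be a 1.1-fold lower number from compound 2 to compound 3 (0.04 log units; within the scatter), not clearly beyond the scatter in either direction. Compound 3 is therefore estimated at 6000 nM, with an expected range from 2000 nM to 20000 nM.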

Compound 3, half-maximal inhibitory concentration: 5580 nM
For compound 3 the middle estimate is 1.1-fold (0.03 log units) above the measured one; low and high end bracket the measured number.
By their numbers in this assay, from the lowest: compounds 3, 2 and 1 (each within the scatter of the next).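

In this assay the exchange of methyl for nitro on an aromatic carbon, ortho to a large group, comes to a 1.2-fold lower number from compound 2 to compound 3 (0.07 log units; within the scatter), so the assay cannot separate these two compounds. For the compounds shown here, this is the first measured pair that differs in only one place, which makes it the first direct reading at this position: nitro, with its 3 heavy atoms and 2 hydrogen-bond acceptors, stands where methyl had 1 heavy atom and no acceptor, and the assay registers no difference beyond its scatter. Nothing at hand bears on what lies behind this result.

A single exchange cannot show whether this position tolerates substitution in general, and a different outcome could still come from an amine, a carboxylic acid or a longer chain in the same place on the ring. Compound 1 differs from compound 2 in more than one place, so it cannot be used to tell whether the 2-methylphenyl to 2-nitrophenyl exchange would read the same on a core that carries a different group in place of the chlorine.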